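The compounds below may be only part of what the source reports. "The series", "measured", "known", "first", "only" and "open" are said of these compounds alone.

Working notes on the chalcone series.

Compound 1 `COc1ccc(C(=O)/C=C/c2ccc(F)cc2)c2c1C=CC(C)(C)O2` sits at a limit in a functional assay on K562 cells (Homo sapiens) for antiproliferative activity, read by MTT assay, with a stated time of 24 h (on this read-out lower numbers stand for stronger inhibition and higher numbers for weaker inhibition), giving > 10000 nM. Compound 2 `COc1ccc(C(=O)/C=C/c2ccc(Br)cc2)c2c1C=CC(C)(C)O2` likewise sits at a limit in this assay, giving > 10000 nM. Within the data shown here, compound 3 `CCN(CC)c1ccc(/C=C/C(=O)c2ccc(OC)c3c2OC(C)(C)C=C3)cc1` is the only member with a measured number, giving 790 nM in this assay. The step of an at least 12-fold lower number from compound 1 to compound 3 (1.10 log units; beyond the scatter) and the step of an at least 12-fold lower number from compound 2 to compound 3 (1.10 log units; beyond the scatter) both point the same way, though the two limits the limit of > 10000 nM in this assay, at which 2 of the 3 values shown sit, leave their true size open. Compound 4 `COc1ccc(C(=O)/C=C/c2ccc(-n3ccnc3)cc2)c2c1C=CC(C)(C)O2` carries the change (1H-imidazol-1-yl in place of diethylamino on an aromatic carbon). Among the measured compounds shown here, no measured step has this change; the halogen analogues and compound 3 bracket the range seen so far. The number for compound 4 in this assay is therefore expected to rise, with the step of a 4.4-fold higher number from compound 3 to compound 4 (0.65 log units; beyond the scatter), giving an estimate of 3500 nM between 900 nM and 12000 nM.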

Compound 4, half-maximal inhibitory concentration: > 10000 nM
Compound 4 was reported as a limit; the forecaster's own chance of this, stated with the estimate: 35%; middle value at least 2.8-fold (0.45 log units) from the limit.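

At this position, on an aromatic carbon para to a large group, 1H-imidazol-1-yl in place of diethylamino gives an at least 12-fold higher number from compound 3 to compound 4 (1.10 log units; beyond the scatter). The earlier compounds shown here set diethylamino only against halogens; compound 4 shows that a nitrogen attached to the ring does not by itself go with the lower number of compound 3. The steps from compound 1 and compound 2 to compound 4 cannot be read, because all three sit at a limit: the limit of > 10000 nM in this assay, at which 3 of the 4 values shown sit.

Any order among these three stays open. Also open, on these data alone, is whether dimethylamino or morpholin-4-yl at this position would keep the number of compound 3.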